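Methoxy Added to the Benzyl Group of Compound 2

The source may report more compounds than this note shows. Statements on the series, on what has been measured and on what is new or still open speak of the compounds shown alone.

Compound 2 `Nc1nc2c(c(=O)n(CC3CC3)c(=O)n2CC2CC2)n1Cc1ccccc1` gives 27% in an assay on isolated protein with dual specificity calcium/calmodulin-dependent 3',5'-cyclic nucleotide phosphodiesterase 1B (Bos taurus) as the target, tested at 100 uM; on this read-out lower numbers stand for less inhibition and higher numbers for more inhibition at the one concentration tested (going by the name of the read-out); its nearest neighbour among the two measured compounds is compound 1 `Cn1c(N)nc2c1c(=O)n(CC1CC1)c(=O)n2CC1CC1`, which gives 30%, and the step of a number 3 percentage points lower from compound 1 to compound 2 (within the scatter) lies within the scatter. Compound 3 `COc1ccc(Cn2c(N)nc3c2c(=O)n(CC2CC2)c(=O)n3CC2CC2)cc1` differs from compound 2 by methoxy in place of hydrogen on an aromatic carbon. Going by the values given here, no measured step alters the benzyl group itself; the only comparison at hand, a number 3 percentage points lower from compound 1 to compound 2 (within the scatter), stayed within the scatter, so nothing points to a move beyond it here. Compound 3 is therefore estimated at 28%, ranging from 10% to 48%, an expected step of a number 1 percentage points higher from compound 2 to compound 3 (within the scatter).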

Compound 3, a percentage reported as inhibition, at one concentration (the size of the read-out at that concentration, not a potency): 60%
Beside the measured number, compound 3's estimate is 32 percentage points below it; the measured number lies above the stated range.
By their numbers in this assay, from the lowest: compounds 2 and 1 (each within the scatter of the next); then compound 3.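

In this assay the benzyl group proves able to move the read-out: methoxy in place of hydrogen on an aromatic carbon, para to a large group, gives a number 33 percentage points higher from compound 2 to compound 3 (beyond the scatter) while plain phenyl had given no step beyond the scatter. Set against the smaller substituent of compound 1, 4-methoxyphenyl likewise gives a number 30 percentage points higher from compound 1 to compound 3 (beyond the scatter) on the same chain carbon. Nothing at hand offers an explanation for this rise.

As far as these compounds go, what an amine, a hydroxyl or ethoxy would do on that carbon stays open. So does whether methoxy elsewhere on the ring would give the same.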